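Adding a second methyl to the aryl ether of compound 2

This account rests on a few compounds, and the source may have more. Where it says the series, first, only, none or still open, it means among the compounds named here.

The three measured compounds share one core and differ only in the aryl group attached through the oxygen. Compound 1 `Cc1ccnc(Oc2ccc(CC3SC(=O)NC3=O)cc2)c1` gives 4280 nM in a functional assay for agonist activity at Free fatty acid receptor 1 (Homo sapiens), read by FLIPR, in the presence of a further agent that is not named here; on this read-out higher numbers stand for an effect only at larger amounts of compound and lower numbers for an effect already at smaller amounts. Compound 2 `Cc1cccc(Oc2ccc(CC3SC(=O)NC3=O)cc2)c1` gives 203 nM in this assay, and compound 3 `O=C1NC(=O)C(Cc2ccc(Oc3ccc(F)cc3)cc2)S1` gives 480 nM. Compound 2 stands lowest of the three: compound 3 lies nearest, a 2.4-fold higher number from compound 2 to compound 3 (0.37 log units; beyond the scatter), and compound 1 furthest, a 21-fold lower number from compound 1 to compound 2 (1.32 log units; beyond the scatter). The remaining step, an 8.9-fold lower number from compound 1 to compound 3 (0.95 log units; beyond the scatter), also exchanges the whole aryl group.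

Compound 4 `Cc1cccc(Oc2ccc(CC3SC(=O)NC3=O)cc2)c1C` keeps the aryl ether of compound 2 and changes it in one place: methyl in place of hydrogen on an aromatic carbon. Among the measured compounds shown here, none of the measured steps adds a methyl to a ring that already carries one; each of them replaces one aryl group with another, so they show only that the choice of the aryl group moves the number strongly, and nothing directly about a further methyl on it. On that basis the expected change from compound 2 to compound 4 is small, a 1.2-fold higher number from compound 2 to compound 4 (0.09 log units; within the scatter), with no clear direction beyond the scatter. Compound 4 is therefore estimated at 250 nM in this assay, within a range from 90 nM to 800 nM.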

Compound 4, half-maximal effective concentration: 334 nM
Estimate against measurement, compound 4: 1.3-fold (0.13 log units) below; measured number inside the range.
By their numbers in this assay, from the lowest: compounds 2, 4 and 3 (each within the scatter of the next, the first and the last beyond it); then compound 1.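

The methyl on this aromatic carbon, ortho to a large group and ortho to a methyl group, gives a 1.6-fold higher number from compound 2 to compound 4 (0.22 log units; within the scatter) in this assay, so compound 2 and compound 4 cannot be told apart. Among the compounds shown here, the earlier steps all exchanged one whole aryl group for another, and the largest of them was a 21-fold lower number from compound 1 to compound 2 (1.32 log units; beyond the scatter); this step is the first to change a single place on the ring, and it shows that a second methyl at this carbon leaves the number within the scatter. Nothing measured here accounts for this result, which rests on one pair of compounds and says nothing of any property of the methyl.

The compounds shown leave open whether this same aromatic carbon would accept a group other than methyl, such as an ethyl group, a methoxy group, a chlorine atom or an amine, with as little effect on the number. They also leave open what the first methyl of compound 2 contributes, as none of them carries a phenyl ring with no methyl at all, and whether a second methyl elsewhere on the ring would behave in the same way.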